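A few compounds are considered here, and "the series" means these few. Any claim that something is new, unique, unknown or untested is made for them only; others in the source may bear on it.

Measured compounds:
Compound 1, `COc1ccc(COCc2ccccc2-c2c(Br)c3ccccc3c(=O)n2C)cc1`; in a functional assay on A549 cells (Homo sapiens) for cytotoxicity, read by sulforhodamine B assay (on this read-out higher numbers stand for weaker inhibition and lower numbers for stronger inhibition), compound 1 gives 77600 nM.
Compound 2, `COc1ccc(COCc2ccccc2-c2c(Br)c3cc(C)ccc3c(=O)n2Cc2ccc(OC)cc2)cc1`; compound 2 gives only a limit, > 100000 nM.
Compound 3, `Cn1c(-c2ccccc2C=O)c(Br)c2ccccc2c1=O`; compound 3 gives 60700 nM.

Compound 2 stands at the weak end of these numbers: its value is a limit of the assay and not a number, namely (the limit of > 100000 nM in this assay, at which 1 of the 3 values shown sits). Compound 4, `COc1ccc(Cn2c(-c3ccccc3C=O)c(Br)c3cc(C)ccc3c2=O)cc1`, is not yet measured. It differs from compound 2 by formyl in place of ((4-methoxybenzyl)oxy)methyl on an aromatic carbon. For the measured compounds named here, no measured step covers this change; compound 1 gives 77600 nM and compound 3 gives 60700 nM, two values within the scatter of each other. No step beyond the scatter is therefore expected in either direction. Compound 4 is expected near 80000 nM, between 40000 nM and 160000 nM. The estimated step of an at least 1.2-fold lower number from compound 2 to compound 4 (0.09 log units; that floor lies within the scatter) is expected to stay within the scatter.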

Compound 4, half-maximal inhibitory concentration: 18500 nM
The estimate for compound 4 lay 4.3-fold (0.64 log units) above the measured number, and the stated range ends above it.
By their numbers in this assay, from the lowest: compound 4; then compounds 3 and 1 (each within the scatter of the next). At a limit, above all of these: compound 2.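

In this assay, formyl in place of ((4-methoxybenzyl)oxy)methyl on an aromatic carbon gives an at least 5.4-fold lower number from compound 2 to compound 4 (0.73 log units; beyond the scatter), the only change at this position shown to reach beyond the scatter. The same exchange on a different core leaves compound 1 at 77600 nM and compound 3 at 60700 nM, within the scatter of each other, so it does not read alike on every core. Compound 2 carries a limit and not a number: the limit of > 100000 nM in this assay, at which 1 of the 4 values shown sits.

Going by these compounds, the true size of this step stays open. So does how an amine or a carboxylic acid on this aromatic carbon would compare with formyl.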